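The source may report more compounds than this note shows. Statements on the series, on what has been measured and on what is new or still open speak of the compounds shown alone.

Measured in a functional assay on NCI-H520 cells (Homo sapiens); a lower number here means a stronger inhibitor of growth, a higher number a weaker inhibitor of growth:

- compound 1 `O=S(=O)(/C=C/c1ccc(Br)cc1)Cc1ccc(Nc2ncnc3ccc(Br)cc23)cc1` gives 20000 nM
- compound 2 `O=S(=O)(/C=C/c1ccc(O)cc1)Cc1ccc(Nc2ncnc3ccc(Br)cc23)cc1` gives 27000 nM

Only these two compounds have been measured, and compound 2, at 27000 nM, lies within the scatter of compound 1. Compound 3 `O=S(=O)(/C=C/c1ccc(Cl)cc1Cl)Cc1ccc(Nc2ncnc3ccc(Br)cc23)cc1` has 2,4-dichlorophenyl in place of 4-hydroxyphenyl on a double-bonded chain carbon bound to a double-bonded chain carbon. Among the measured compounds shown here, one measured step bears on this change: a 1.4-fold higher number from compound 1 to compound 2 (0.13 log units; within the scatter), with hydroxy in place of bromo on an aromatic carbon. That step lies within the scatter, so swapping this substituent has shown little so far. For the measured compounds named here, no measured compound carries 2,4-dichlorophenyl, however, so the evidence is thin. No step beyond the scatter is therefore expected in this assay. The expected step is a 1.4-fold lower number from compound 2 to compound 3 (0.13 log units; within the scatter). For compound 3 the estimated value is 20000 nM, with an expected range from 8000 nM to 45000 nM.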

Compound 3, concentration for 50% growth inhibition: 8000 nM
Beside the measured number, compound 3's estimate is 2.5-fold (0.40 log units) above it; low and high end bracket the measured number.
By their numbers in this assay, from the lowest: compound 3; then compounds 1 and 2 (each within the scatter of the next).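

Replacing the aryl group on the double-bonded chain carbon can change growth inhibition: in this assay, 2,4-dichlorophenyl gives a 3.4-fold lower number from compound 2 to compound 3 (0.53 log units; beyond the scatter), and against 4-bromophenyl it gives a 2.5-fold lower number from compound 1 to compound 3 (0.40 log units; beyond the scatter). Hydroxy and bromo on the ring had stayed within the scatter of each other, so these modest steps are the first sign that this position responds to a substituent change. Nothing measured here explains the shift.

On these data alone, it remains open whether both chlorines of 2,4-dichlorophenyl are needed, or whether a single chlorine on the ring would give the same result. As far as these compounds go, it is also open how a ring carrying a different group, such as an amine, a carboxylic acid or trifluoromethyl, would perform in this assay.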